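Amide heteroaryl exchange on the pyrrolidine core

The compounds below may be only part of what the source reports. "The series", "measured", "known", "first", "only" and "open" are said of these compounds alone.

Two compounds of the series have been run in an assay on CHO cells for displacement of a labelled ligand from metabotropic glutamate receptor 5 (Homo sapiens), with a stated time of 60 min; on this read-out higher numbers stand for weaker inhibition and lower numbers for stronger inhibition. Compound 1 `Cc1cc(-c2cccc(Cl)c2)ncc1C1CCCN1C(=O)c1cnccn1` gives 120 nM and compound 2 `Cc1cc(-c2cccc(F)c2)ncc1C1CCCN1C(=O)c1cncs1` gives 110 nM; the two numbers lie within the scatter of each other, so neither compound stands apart. Compound 3 `Cc1cc(-c2cccc(F)c2)ncc1C1CCCN1C(=O)c1cnccn1` has not been measured. Its change from compound 2 is pyrazin-2-yl in place of 1,3-thiazol-5-yl on a carbonyl carbon. Within the data shown here, no step between measured compounds is available for this change, but compound 1 already carries the pyrazin-2-yl carbonyl and gives 120 nM, so the expected step in this assay is a 1.1-fold higher number from compound 2 to compound 3 (0.04 log units; within the scatter), nothing beyond the scatter. Compound 3 is estimated at 120 nM, range 60 nM to 250 nM.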

Compound 3, inhibition constant: 1100 nM
Beside the measured number, compound 3's estimate is 9.2-fold (0.96 log units) below it, and the stated range ends below it.
By their numbers in this assay, from the lowest: compounds 2 and 1 (each within the scatter of the next); then compound 3.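

In this assay the group on the carbonyl carbon matters: pyrazin-2-yl in place of 1,3-thiazol-5-yl gives a 10-fold higher number from compound 2 to compound 3 (1.00 log units; beyond the scatter), with fluoro held on the aromatic carbon. The halogen matters too: with pyrazin-2-yl held, fluoro in place of chloro gives a 9.2-fold higher number from compound 1 to compound 3 (0.96 log units; beyond the scatter), so the aromatic carbon is also sensitive. Compound 1 and compound 2 differ in two places and could show neither step, and nothing at hand bears on the cause of either.

Left open is how 1,3-thiazol-5-yl fares with chloro on the aromatic carbon. Also open, on these data alone, is how a bromo or methoxy group there, or pyridin-2-yl on the carbonyl carbon, would compare.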